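The source may report more compounds than this note shows. Statements on the series, on what has been measured and on what is new or still open speak of the compounds shown alone.

Measured compounds:
- Compound 1 `CCc1ccccc1OS(=O)(=O)c1cccc(NC(=O)NCCCCl)c1` gives 23000 nM in a functional assay on HT-29 cells (Homo sapiens) for cytotoxicity, read by sulforhodamine B assay, with a stated time of 48 h; a higher number here means a weaker inhibitor, a lower number a stronger inhibitor
- Compound 2 `Cc1ccccc1OS(=O)(=O)c1ccc(NC(=O)NCCCCl)cc1` gives 26000 nM in this assay
- Compound 3 `CCc1ccccc1OS(=O)(=O)c1ccc(NC(=O)NCCCCl)cc1` gives 15000 nM in this assay

Compound 3 has the lowest of the three numbers, but its gaps to compound 1 and compound 2 both lie within the scatter, so the three compounds are not distinguishable on the numbers shown. Compound 4 `CCCc1ccccc1OS(=O)(=O)c1ccc(NC(=O)NCCCCl)cc1` has not yet been measured. It differs from compound 3 by methyl in place of hydrogen on a saturated chain carbon, two bonds along the chain from an aromatic carbon on the aryl group that carries the sulfonate oxygen.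

Going by the values given here, only one measured step bears directly on this kind of change: a 1.7-fold lower number from compound 2 to compound 3 (0.24 log units; within the scatter), which extends the same chain by one carbon at the position one bond closer to the ring. That step stayed within the scatter. Among the compounds with values here, nothing measured speaks to the second extension, and no compound in the set carries a propyl chain. Within the data shown here, the step from compound 3 to compound 4 is therefore expected to be small, probably not beyond the scatter, with at most a slight lean toward a lower number in line with the one prior step. The estimate for compound 4 is 12000 nM (range 5000 nM to 30000 nM), an expected step of a 1.3-fold lower number from compound 3 to compound 4 (0.10 log units; within the scatter).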

Compound 4, half-maximal inhibitory concentration: 13000 nM
Compound 4: the middle estimate sits 1.1-fold (0.03 log units) below what was measured, and the stated range covers the measured number.
By their numbers in this assay, from the lowest: compounds 4, 3, 1 and 2 (each within the scatter of the next).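

Replacing 2-ethylphenyl with 2-propylphenyl, which puts methyl in place of hydrogen on a saturated chain carbon, two bonds along the chain from an aromatic carbon, gives in this assay a 1.2-fold lower number from compound 3 to compound 4 (0.06 log units; within the scatter) and thus shows that a second chain extension also stays inside the scatter. Taken as one change, the two chain extensions together give a 2.0-fold lower number from compound 2 to compound 4 (0.30 log units; within the scatter) and so, unlike the earlier compounds, test a change of two added carbons, which still does not leave the scatter. No measurement in hand accounts for the size of either step.

Going by these compounds, whether a longer chain such as butyl or pentyl, a branched chain such as isopropyl, or an amine or carboxylic acid at the end of the chain would move the number beyond the scatter remains open. Also open is whether 2-propylphenyl would give a similarly small step on the core of compound 1, where only 2-ethylphenyl is shown.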